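Chloro to fluoro on the benzylidene aryl of compound 2

The compounds below may be only part of what the source reports. "The series", "measured", "known", "first", "only" and "open" are said of these compounds alone.

Measured compounds
compound 1, `C=C(C/C(=C\c1ccccc1)C(=O)c1ccccc1)C(=O)c1ccccc1`: 3000 nM
compound 2, `C=C(C/C(=C\c1ccc(Cl)cc1)C(=O)c1ccccc1)C(=O)c1ccccc1`: 6100 nM

Compound 2 carries the higher of the two numbers in a functional assay on SW1573 cells (Homo sapiens) for inhibition, read by sulforhodamine B assay, with a stated time of 48 h; on this read-out lower numbers stand for stronger inhibition of growth and higher numbers for weaker inhibition of growth. Within the data shown here, its only neighbour among the measured compounds is compound 1, and the one step between them, a 2.0-fold higher number from compound 1 to compound 2 (0.31 log units; beyond the scatter), is modest yet beyond the scatter: adding chloro in place of hydrogen on an aromatic carbon weakened growth inhibition.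

Compound 3, `C=C(C/C(=C\c1ccc(F)cc1)C(=O)c1ccccc1)C(=O)c1ccccc1`, has not been measured in this assay. It differs from compound 2 by fluoro in place of chloro on an aromatic carbon. Cut one bond further out, the difference reads 4-chlorophenyl to 4-fluorophenyl, with the halogen placed on an aromatic carbon of a six-membered aromatic ring of carbon only, para to a large group.

Among the measured compounds shown here, no measured step swaps one halogen for another. For the measured compounds named here, the only step bearing on this position is the one from hydrogen to chloro in compound 2, a 2.0-fold higher number from compound 1 to compound 2 (0.31 log units; beyond the scatter); fluoro counts one heavy atom like chloro but is nearer to hydrogen, so the number for compound 3 is expected to fall between those of compound 1 and compound 2, most likely within the scatter of either. Compound 3 is thus estimated at 4300 nM, in the range 2200 nM to 8500 nM, which would be a step of a 1.4-fold lower number from compound 2 to compound 3 (0.15 log units; within the scatter).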

Compound 3, concentration for 50% growth inhibition: 3500 nM
For compound 3 the middle estimate is 1.2-fold (0.09 log units) above the measured one; the measured number falls inside the stated range.
By their numbers in this assay, from the lowest: compounds 1, 3 and 2 (each within the scatter of the next, the first and the last beyond it).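

Notes on the aryl halogen: in this assay, a direct swap of one halogen for another at this position can now be read, and fluoro in place of chloro gives a 1.7-fold lower number from compound 2 to compound 3 (0.24 log units; within the scatter) with no separation between the two. Fluoro in place of hydrogen gives a 1.2-fold higher number from compound 1 to compound 3 (0.07 log units; within the scatter), so compound 3 is not separated from compound 1 either. Compound 3 therefore sits within the scatter of both neighbours, and the only separated pair remains the one that differs by chloro in place of hydrogen (a 2.0-fold higher number from compound 1 to compound 2 (0.31 log units; beyond the scatter)), so the weaker growth inhibition seen with 4-chlorophenyl is not shown to extend to 4-fluorophenyl.

Nothing available accounts for these numbers. Still open, on these data alone, is whether a group other than a halogen at this same place on the aromatic ring, such as methoxy, an amine or a carboxylic acid, would give a number beyond the scatter of compound 1, and whether the other places on the core of compound 1 respond in the same way.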